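Methoxy for Methyl on Two Arrangements of One Core

The compounds below may be only part of what the source reports. "The series", "measured", "known", "first", "only" and "open" are said of these compounds alone.

Compound 1 `Cc1ccccc1NC(=S)N1CCc2c(sc(NC(=O)c3ccccc3Cl)c2C(N)=O)C1` and compound 2 `COc1ccccc1NC(=S)N1CCc2c(sc(NC(=O)c3ccccc3Cl)c2C(N)=O)C1` share a core and differ by methoxy in place of methyl on an aromatic carbon. In a functional assay on HeLa cells (Homo sapiens) for antiproliferative activity, with a stated time of 24 h (on this read-out lower numbers stand for stronger inhibition and higher numbers for weaker inhibition), compound 1 reaches only the limit > 50000 nM. Compound 2 likewise gives only the limit > 50000 nM in this assay. The step that the two limits leave unreadable from compound 1 to compound 2 is thus unreadable, as both values sit at the limit of > 50000 nM in this assay, at which 2 of the 3 values shown sit. Compound 3 `Cc1ccccc1C(=O)Nc1sc2c(c1C(N)=O)CCN(C(=S)Nc1ccccc1Cl)C2` has the same atoms joined differently; the difference between the two cores is not broken down here. In this assay compound 3 gives 35300 nM. Compound 4 `COc1ccccc1C(=O)Nc1sc2c(c1C(N)=O)CCN(C(=S)Nc1ccccc1Cl)C2` arises from compound 3 by methoxy in place of methyl on an aromatic carbon, the same change in the same place. Because the earlier step that the two limits leave unreadable from compound 1 to compound 2 gave no readable size, the expected step of a 1.1-fold higher number from compound 3 to compound 4 (0.05 log units; within the scatter) rests on compound 3 alone and is estimated as small, with a limit possible. Compound 4 is expected near 40000 nM, between 15000 nM and 120000 nM.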

Compound 4, half-maximal inhibitory concentration: > 50000 nM
Compound 4: a limit, no number; the forecaster's own chance of this, stated with the estimate: 40%; at least 1.2-fold (0.09 log units) between middle value and limit.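

Carried onto the second arrangement of the core, methoxy in place of methyl gives an at least 1.4-fold higher number from compound 3 to compound 4 (0.15 log units; that floor lies within the scatter). In this assay, on these data alone, compound 4 gives > 50000 nM, a limit and not a number, so the true size of this step remains unknown. The step on the first arrangement cannot be read, so the two cores cannot be compared for this change, and the read-out's ceiling governs most of the series: the limit of > 50000 nM in this assay, at which 3 of the 4 values shown sit.

The compounds shown leave open how far the methoxy group lowers activity on either core, if it does so at all. As far as these compounds go, how an amine or a carboxylic acid at this place on the ring would read in this assay also stays open.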